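A few compounds are considered here, and "the series" means these few. Any claim that something is new, unique, unknown or untested is made for them only; others in the source may bear on it.

Measured so far:
compound 1 `Cc1nc2c(OCc3cccs3)cccn2c1N` gives 70% in a functional assay on the whole organism with Rattus norvegicus as the target, at a dose of 40 mg/kg by the intraperitoneal route; on this read-out higher numbers stand for more inhibition at the one dose given (going by the name of the read-out) and lower numbers for less inhibition
compound 2 `Cc1nc2c(OCc3ccccc3)cccn2c1NC=O` gives 49% in this assay

Compound 2 stands lowest of the two numbers shown; compound 1 is its nearest neighbour and sits higher by a gap beyond the usual scatter. Going by the values given here, no step between measured compounds that differ in one place is available, and compound 1 and compound 2 differ in more than one place, so their two values can only be set side by side.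

Compound 3 `CNC(=O)Nc1c(C)nc2c(OCc3ccccc3)cccn12` is not yet measured. It differs from compound 2 in one place: methylamino in place of hydrogen on a carbonyl carbon Cut one bond further out, formyl becomes methylcarbamoyl and formylamino becomes (methylcarbamoyl)amino. Among the compounds with values here, no measured pair speaks to this change, so in this assay the expected step of a number 1 percentage points higher from compound 2 to compound 3 (within the scatter) is none beyond the scatter, in no firm direction. Compound 3 is expected to give 50%, estimated between 25% and 75%.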

Compound 3, a percentage reported as inhibition, in the whole organism at one dose (the size of the read-out at that dose, not a potency): 22%
Compound 3: the middle estimate sits 28 percentage points above what was measured; measured number below the stated range.
By their numbers in this assay, from the lowest: compound 3; then compound 2; then compound 1.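

Formylamino to (methylcarbamoyl)amino is the first change in the series that can be read in one place, and in this assay it gives a number 27 percentage points lower from compound 2 to compound 3 (beyond the scatter) at the one dose given. The carbonyl carbon of this group is therefore not indifferent to what it carries: with an amide-type nitrogen as its other neighbour, methylamino in place of hydrogen goes with less inhibition, a finding that rests on this single pair. Going by these compounds alone, nothing measured so far bears on why the read-out falls with this change.

Going by these compounds, whether the fall belongs to methylamino in particular or to any group larger than hydrogen on this carbon remains open. A methyl group, a plain amino group or a methoxy group at this carbon, on the core of compound 2, would separate these readings.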